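Moving the chlorine around the phenyl ring of compound 1

The source may hold more compounds than are shown below. What is called first, only, known or untested is meant among the compounds shown, and "the series" means these compounds.

In a functional assay on microsomes for inhibition, with a stated time of 1 h (on this read-out lower numbers stand for stronger inhibition and higher numbers for weaker inhibition), compound 1 `CCOC(=O)c1cnn(-c2nc(-c3ccccc3Cl)c(C#N)c(=O)n2C)c1N` gives 102 ug/mL. Among the compounds with values here, compound 2 `Cn1c(NN)nc(-c2ccco2)c(C#N)c1=O`, a different scaffold in the same series, gives 78 ug/mL in this assay; the gap between the two numbers lies within the usual scatter, so compound 1 stands level with its only neighbour. Compound 3 `CCOC(=O)c1cnn(-c2nc(-c3ccc(Cl)cc3)c(C#N)c(=O)n2C)c1N` differs from compound 1 in one place: 4-chlorophenyl in place of 2-chlorophenyl on an aromatic carbon. Within the data shown here, no measured pair shows what such a change does here, so no step beyond the scatter is expected in either direction. Compound 3 is therefore estimated at 100 ug/mL, within 50 ug/mL to 200 ug/mL, a step of a 1.0-fold lower number from compound 1 to compound 3 (0.01 log units; within the scatter).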

Compound 3, half-maximal inhibitory concentration: 88 ug/mL
Compound 3: middle estimate off by 1.1-fold (0.06 log units), on the high side; low and high end bracket the measured number.
By their numbers in this assay, from the lowest: compounds 2, 3 and 1 (each within the scatter of the next).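

In this assay the change from 2-chlorophenyl to 4-chlorophenyl gives a 1.2-fold lower number from compound 1 to compound 3 (0.06 log units; within the scatter) and forms the only pair shown that differs in one place. On this read-out, the two placements of the chlorine on the phenyl ring cannot be told apart. Nothing measured here bears on this result. As far as these compounds go, it remains open whether a methoxy group or an amine in place of the chlorine would give a step beyond the scatter. Also open, from the compounds shown here alone, is what a carboxylic acid in place of the ethyl ester would do.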